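This account rests on a few compounds, and the source may have more. Where it says the series, first, only, none or still open, it means among the compounds named here.

Values measured in an ADME assay on HUVEC cells (Homo sapiens) for cytotoxicity, read by MTT assay, with a stated time of 24 h (a lower number here means a stronger inhibitor, a higher number a weaker inhibitor), are as follows.

Compound 1 `COCC1Oc2ccc(-c3oc4cc(O)cc(O)c4c(=O)c3OC)cc2OC1c1ccc(O)c(OC)c1`: 60900 nM
Compound 2 `COc1cc(C2Oc3cc(-c4oc5cc(O)cc(O)c5c(=O)c4O)ccc3OC2COC(=O)c2cc(O)c(O)c(O)c2)ccc1O`: 11500 nM
Compound 3 `COCC1Oc2ccc(-c3oc4cc(OC)cc(O)c4c(=O)c3O)cc2OC1c1ccc(O)c(OC)c1`: 14500 nM

Compound 3 stands within the scatter of compound 2, so the two cannot be ranked against each other. Compound 1 gives a higher number than compound 3, and that gap lies beyond the scatter.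

The account now turns to compound 4 `COCC1Oc2ccc(-c3oc4cc(O)cc(O)c4c(=O)c3O)cc2OC1c1ccc(O)c(OC)c1`, which has not yet been measured in this assay. It departs from compound 3 in one place, where methoxy becomes hydroxy: hydrogen in place of methyl on an oxygen on an aromatic ring. This puts hydrogen in place of methyl on an oxygen on an aromatic ring.

Within the data shown here, no two measured compounds differ in only one place, so the data offer no direct precedent for this change. The nearest guide is compound 3 itself, at 14500 nM in the same test. Compound 4 is therefore expected to show no step beyond the scatter, with only a slight lean towards a lower number and no firm direction. The estimated move is a 1.1-fold lower number from compound 3 to compound 4 (0.05 log units; within the scatter) and remains an expectation until measured. For compound 4 the estimated value is 13000 nM, with an expected range from 5500 nM to 32000 nM in this test.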

Compound 4, half-maximal inhibitory concentration: 28300 nM
Compound 4: middle estimate off by 2.2-fold (0.34 log units), on the low side, within the range that was stated.
By their numbers in this assay, from the lowest: compounds 2, 3 and 4 (each within the scatter of the next, the first and the last beyond it); then compound 1.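

In this assay, the exchange of methyl for hydrogen on an oxygen on an aromatic ring can now be read at two different oxygens of the shared core: a 2.0-fold higher number from compound 3 to compound 4 (0.29 log units; within the scatter) stays within the scatter, so methoxy and hydroxy cannot be told apart at this position, whereas a 2.2-fold lower number from compound 1 to compound 4 (0.33 log units; beyond the scatter) is a modest step beyond it. The same named change therefore does not read alike at these two oxygens, at least in this small set. Among these compounds, the first reading on the oxygen on a saturated carbon is also modest but beyond the scatter, with a 2.5-fold higher number from compound 2 to compound 4 (0.39 log units; beyond the scatter) as methyl takes the place of (3,4,5-trihydroxyphenyl)carbonyl, and nothing measured here accounts for any of these steps.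

The compounds shown leave open how a longer chain such as ethyl, or an amine in place of the oxygen, would read at the position where compound 3 and compound 4 differ. They also leave open how a simple acetyl group on the oxygen on a saturated carbon would compare with the methyl of compound 4 and the larger ester of compound 2.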